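A few compounds are considered here, and "the series" means these few. Any claim that something is new, unique, unknown or untested is made for them only; others in the source may bear on it.

Among the measured compounds shown here, compound 2 `COc1cc(-c2cc(/C=C/C(=O)c3ccc(N)cc3)[nH]n2)cc(OC)c1OC` gives 102% in a functional assay on NCI-H23 cells (Homo sapiens) for cytotoxicity, read by sulforhodamine B assay, with a stated time of 48 h, tested at 0.01 uM (on this read-out lower numbers stand for a stronger effect and higher numbers for a weaker effect at the one concentration tested), the highest of the two numbers measured, though its nearest neighbour, compound 1 `COc1ccc(-c2cc(/C=C/C(=O)c3ccc(N)cc3)[nH]n2)cc1`, gives 92% in this assay, a reading that lies within the scatter of the one for compound 2. Both readings show little effect at the single concentration tested. Compound 3 `COc1ccc(C(=O)/C=C/c2cc(-c3cc(OC)c(OC)c(OC)c3)n[nH]2)cc1` differs from compound 2 by methoxy in place of amino on an aromatic carbon. For the measured compounds named here, with no step between measured compounds to lean on, the change from compound 2 to compound 3 is expected to bring no step beyond the scatter, a number 4 percentage points lower from compound 2 to compound 3 (within the scatter). Compound 3 is therefore estimated at 98% in this assay, within a range from 85% to 110%.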

Compound 3, a percentage reported as activity, at one concentration (the size of the read-out at that concentration, not a potency): 93%
Estimate against measurement, compound 3: 5 percentage points above, within the range that was stated.
By their numbers in this assay, from the lowest: compounds 1, 3 and 2 (each within the scatter of the next).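

Methoxy in place of amino, para to a large group, gives a number a number 9 percentage points lower from compound 2 to compound 3 (within the scatter) in this assay and so leaves the reading within the scatter. The 4-aminophenyl group can thus give way to 4-methoxyphenyl, with one hydrogen-bond donor fewer, without a change beyond the scatter at this single concentration. Nothing available explains this result.

Going by these compounds, all three compounds show little effect at this concentration, so it stays open whether this position matters at higher concentrations. On these data alone, it also stays open whether a hydroxy group or a carboxylic acid on this carbon would move the reading beyond the scatter.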